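Exposure notes: methylation of the amide nitrogen

The source may hold more compounds than are shown below. What is called first, only, known or untested is meant among the compounds shown, and "the series" means these compounds.

Compound 1 `CCCCN(c1nc2c(CO)cccc2o1)[C@H](C)c1ccc(-c2ccccc2-c2nnn[nH]2)cc1` — 20 ng.h/mL
Compound 2 `CCCCN(c1nc2c(C(=O)NC)cccc2o1)[C@H](C)c1ccc(-c2ccccc2-c2nnn[nH]2)cc1` — 25.7 ng.h/mL

In an ADME assay on the whole organism (Macaca fascicularis) for pharmacokinetics, read by LC-MS, using cassette dosing, at a dose of 1 mg/kg by the oral route (a lower number here means less compound in the circulation, a higher number more compound in the circulation at the dose given), compound 1 gives 20 ng.h/mL, and compound 2 gives 25.7 ng.h/mL. The step of a 1.3-fold higher number from compound 1 to compound 2 (0.11 log units; within the scatter) shows that putting methylcarbamoyl in place of hydroxymethyl on an aromatic carbon left exposure unchanged within the scatter, so compound 2 sits at the higher of two numbers that cannot be separated. Compound 3 `CCCCN(c1nc2c(C(=O)N(C)C)cccc2o1)[C@H](C)c1ccc(-c2ccccc2-c2nnn[nH]2)cc1` carries the change (methyl in place of hydrogen on an amide-type nitrogen). For the measured compounds named here, no measured step touches an amide-type nitrogen; the single step known so far concerns another place and lay within the scatter, so it gives no direction for this one. The expectation is therefore no movement beyond the scatter, with the range widened for want of a precedent. The step expected is a 1.1-fold higher number from compound 2 to compound 3 (0.04 log units; within the scatter). For compound 3 the estimated value is 28 ng.h/mL, with a range from 10 ng.h/mL to 75 ng.h/mL.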

Compound 3, area under the concentration-time curve: 104 ng.h/mL
Estimate against measurement, compound 3: 3.7-fold (0.57 log units) below, outside the stated range (above it).
By their numbers in this assay, from the lowest: compounds 1 and 2 (each within the scatter of the next); then compound 3.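

In this assay, methyl in place of hydrogen on an amide-type nitrogen gives a 4.0-fold higher number from compound 2 to compound 3 (0.61 log units; beyond the scatter) and so moves exposure beyond the scatter with a single added heavy atom. Against hydroxymethyl on the same aromatic carbon, dimethylcarbamoyl gives a 5.2-fold higher number from compound 1 to compound 3 (0.72 log units; beyond the scatter) while methylcarbamoyl does not separate from hydroxymethyl, so among these compounds the amide separates from hydroxymethyl only once the amide hydrogen is replaced. Nothing in hand gives a cause for the rise.

The compounds shown do not tell whether the gain comes from losing the amide hydrogen or from the added methyl itself. Diethylcarbamoyl would test whether longer chains on the nitrogen hold the gain, and a carboxylic acid on the same aromatic carbon would show how far this position tolerates a different group.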